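The source may hold more compounds than are shown below. What is called first, only, known or untested is meant among the compounds shown, and "the series" means these compounds.

Compound 1 `CCCCSC(=S)C1=C(Nc2ccc(Cl)cc2Cl)CC(C)(C)CC1=O` and compound 2 `CCCCSC(=S)C1=C(Nc2ccc(Br)cc2)CC(C)(C)CC1=O` share the same core and the same butylsulfanyl chain, and differ only in the group carried on the amine nitrogen. In a functional assay on cells (blood, Homo sapiens) for inhibition, read by chemiluminescence, with a stated time of 30 min (a higher number here means a weaker inhibitor, a lower number a stronger inhibitor), compound 1 gives > 100 ug/mL, which is a limit of the assay and not a number. In this assay compound 2 gives > 100 ug/mL, likewise a limit rather than a number. The step that the two limits leave unreadable from compound 1 to compound 2 therefore cannot be sized in either direction, because the limit of > 100 ug/mL in this assay, at which 2 of the 2 values shown sit, leaves no number on either side to compare. Compound 3 `CC1(C)CC(=O)C(C(=S)SCCO)=C(Nc2ccc(Br)cc2)C1` keeps the 4-bromophenyl of compound 2 on the amine nitrogen and alters only the chain: hydroxy in place of ethyl on a saturated chain carbon, two bonds along the chain from a sulfur. No measured step touches this part of the molecule, and the single step shown is itself unreadable, so nothing in the data points to a direction. The step that the limit leaves unreadable from compound 2 to compound 3 is accordingly expected to be no larger than the usual scatter. In this assay compound 3 is expected to give about 150 ug/mL, somewhere between 60 ug/mL and 400 ug/mL, most likely again reported only as a limit.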

Compound 3, half-maximal inhibitory concentration: > 100 ug/mL
Compound 3: only a limit was reported (the forecaster's own chance of this, stated with the estimate: 85%); the middle value is on the limit's open side.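

The step from compound 2 to compound 3 cannot be read, because both compounds give only a limit of the assay and not a number: the limit of > 100 ug/mL in this assay, at which 3 of the 3 values shown sit.

The compounds shown leave open how strong compound 1, compound 2 and compound 3 really are in this assay, and whether changing the group on the amine nitrogen or the chain alters that strength at all.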